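Chain length on the ring nitrogen of the trimethoxybenzyl series

This account rests on a few compounds, and the source may have more. Where it says the series, first, only, none or still open, it means among the compounds named here.

Measured so far in a functional assay on MCF7 cells (Homo sapiens) for antiproliferative activity; a lower number here means a stronger inhibitor, a higher number a weaker inhibitor:
compound 1 `CCCCn1c(Cc2cc(OC)c(OC)c(OC)c2)nc2c(N)nc(F)nc21`: 24000 nM
compound 2 `CCC(CC)Cn1c(Cc2cc(OC)c(OC)c(OC)c2)nc2c(N)ncnc21`: 158000 nM
compound 3 `CC/C=C\Cn1c(Cc2cc(OC)c(OC)c(OC)c2)nc2c(N)ncnc21`: 64600 nM

Compound 1 gives the lowest number of the three in this assay; compound 3 sits nearest and compound 2 furthest, both gaps beyond the scatter. Compound 1 also differs from compounds 2 and 3 in carrying a fluorine on the core, so its position cannot be attributed to the chain alone.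

Within the data shown here, the only step between measured compounds, a 2.4-fold lower number from compound 2 to compound 3 (0.39 log units; beyond the scatter), swaps a branched saturated chain for an unsaturated one on the carbon bound to the aromatic nitrogen. It does not touch the end of the chain and so bears only loosely on the present question.

Compound 4 `CCCCCn1c(Cc2cc(OC)c(OC)c(OC)c2)nc2c(N)nc(F)nc21` is compound 1 with methyl in place of hydrogen on a saturated chain carbon, four bonds along the chain from an aromatic nitrogen. Among the measured compounds shown here, no measured pair shows what adding one carbon at the end of the chain does here; the sole step recorded concerns a different part of the chain. The expectation is therefore a step from compound 1 to compound 4 of no clear direction and not beyond the scatter, a 1.1-fold lower number from compound 1 to compound 4 (0.04 log units; within the scatter). Compound 4 is estimated at 22000 nM, with a range from 8000 nM to 60000 nM.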

Compound 4, half-maximal inhibitory concentration: 36300 nM
Compound 4: the middle estimate sits 1.7-fold (0.22 log units) below what was measured; low and high end bracket the measured number.
By their numbers in this assay, from the lowest: compounds 1, 4 and 3 (each within the scatter of the next, the first and the last beyond it); then compound 2.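

In this assay, methyl in place of hydrogen on a saturated chain carbon, four bonds along the chain from an aromatic nitrogen, gives a 1.5-fold higher number from compound 1 to compound 4 (0.18 log units; within the scatter). Among these compounds, this is the first pair that differs at the end of the chain with the fluorine-bearing core held constant, and at this position the added methyl leaves the number within the usual scatter, so this single step shows no measurable sensitivity to the change. No measured information on the compounds bears on this result, so it stands here as an observation only.

On these data alone, one step sets no trend along the chain, so it stays open whether a longer chain such as hexyl, or a hydroxyl or an amine at the chain end, would keep the number within the scatter of compound 1. Also open are what the fluorine on the core contributes, as no pair shown differs only there, and whether the same methyl change would read alike on the core of compound 2 and compound 3, which lacks that fluorine.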